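This account rests on a few compounds, and the source may have more. Where it says the series, first, only, none or still open, it means among the compounds named here.

Measured in a functional assay on the whole organism for inhibition, with Rattus norvegicus as the target, at a dose of 1 mg/kg by the oral route; a higher number here means a stronger effect of the compound at the dose given, a lower number a weaker effect:
compound 1 `CCc1ccnc(C(=O)Nc2nn[nH]n2)c1` gives 32%
compound 2 `Cc1cccc(C(=O)Nc2nn[nH]n2)n1` gives 40%
compound 3 `Cc1ccnc(C(=O)Nc2nn[nH]n2)c1` gives 28%

Compound 3 stands lowest of the three numbers. Its nearest neighbour is compound 1, whose number is higher by a margin within the scatter, so the two cannot be ordered; its furthest is compound 2, whose number is higher by a margin beyond the scatter.

Compound 4 `O=C(Nc1nn[nH]n1)c1ccccn1` has not yet been measured. Against compound 3 the change is hydrogen in place of methyl on an aromatic carbon.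

Among the measured compounds shown here, one measured step bears on this: a number 4 percentage points lower from compound 1 to compound 3 (within the scatter). That step also exchanged a methyl for hydrogen, though on a saturated chain carbon bound to an aromatic carbon rather than on the aromatic ring itself, and it stayed within the scatter. For the measured compounds named here, no measured step removes a methyl from an aromatic carbon, so the present change rests on a single, only partly comparable precedent. On that basis the expected step in this assay is small and of no fixed direction: the step of no change at the digits printed from compound 3 to compound 4 (within the scatter) is what the estimate assumes, a step not expected to exceed the scatter.

Compound 4 is therefore estimated at 28%, with a range from 14% to 42%. The chance that only a limit is reported is judged low.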

Compound 4, a percentage reported as inhibition, in the whole organism at one dose (the size of the read-out at that dose, not a potency): 0%
The estimate for compound 4 lay 28 percentage points above the measured number; measured number below the stated range.
By their numbers in this assay, from the lowest: compound 4; then compounds 3, 1 and 2 (each within the scatter of the next, the first and the last beyond it).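

Working from this assay, the opposite-the-ring-nitrogen carbon proves more sensitive than the earlier compounds suggested: swapping methyl for ethyl there gave only a number 4 percentage points lower from compound 1 to compound 3 (within the scatter), but removing the alkyl group altogether gives a number 28 percentage points lower from compound 3 to compound 4 (beyond the scatter) and, for ethyl, a number 32 percentage points lower from compound 1 to compound 4 (beyond the scatter), so at this dose the presence of an alkyl group counts for more than which of these two it is. The unsubstituted compound 4, at 0%, also sits well under the isomeric methyl compound, with a number 40 percentage points lower from compound 2 to compound 4 (beyond the scatter), so a methyl at a different ring carbon likewise carries a measurable effect and the gain is not confined to one carbon among the compounds shown. Nothing at hand explains why the loss of the alkyl group has so large an effect.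

Still open, from the compounds shown here alone, is whether a longer chain such as propyl or butyl at this carbon would go beyond the number of compound 1, or whether the effect ends with small alkyl groups. Going by these compounds, it is equally open whether a non-alkyl group there, such as methoxy, chlorine or an amine, could stand in for the methyl of compound 3.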